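From 4-Chlorophenyl to 3-Iodophenyl: A Step Not Yet Measured

The source may hold more compounds than are shown below. What is called first, only, known or untested is meant among the compounds shown, and "the series" means these compounds.

Compound 1 `COc1ccccc1Oc1c(N)nc(-c2ccccc2)nc1Cl` gives 4610 nM
Compound 2 `COc1ccccc1Oc1c(N)nc(-c2ccc(C)cc2)nc1Cl` gives 17400 nM
Compound 3 `COc1ccccc1Oc1c(N)nc(-c2ccc(Cl)cc2)nc1Cl` gives 18800 nM

In a functional assay on B16 cells (Mus musculus) for cytotoxicity, read by CCK-8 assay, with a stated time of 24 h (a lower number here means a stronger inhibitor, a higher number a weaker inhibitor), compound 3 gives 18800 nM and, with compound 2, sits on the weaker side of this small set. The two are not separated, since the chloro for methyl exchange amounts to a 1.1-fold higher number from compound 2 to compound 3 (0.03 log units; within the scatter). For the measured compounds named here, compound 1, which has neither group, is the only member that stands apart from both.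

The next compound is compound 4 `COc1ccccc1Oc1c(N)nc(-c2cccc(I)c2)nc1Cl`, where 3-iodophenyl takes the place of 4-chlorophenyl on an aromatic carbon: 3-iodophenyl in place of 4-chlorophenyl on an aromatic carbon.

Going by the values given here, two measured steps bear on this change. Adding methyl gave a 3.8-fold higher number from compound 1 to compound 2 (0.58 log units; beyond the scatter), and adding chloro gave a 4.1-fold higher number from compound 1 to compound 3 (0.61 log units; beyond the scatter). Both are modest, and both point towards a higher number when a group is added to the plain phenyl of compound 1. Among the compounds with values here, neither tells how iodo behaves, and no measured compound carries a group where 3-iodophenyl carries it. Compound 4 therefore keeps a substituted phenyl, and no clear shift from compound 3 is expected, only a slight lean back towards compound 1. The estimated change is a 1.6-fold lower number from compound 3 to compound 4 (0.19 log units; within the scatter). For compound 4 the estimated value is 12000 nM, with an expected range of 4500 nM to 32000 nM.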

Compound 4, half-maximal inhibitory concentration: 27600 nM
Beside the measured number, compound 4's estimate is 2.3-fold (0.36 log units) below it, within the range that was stated.
By their numbers in this assay, from the lowest: compound 1; then compounds 2, 3 and 4 (each within the scatter of the next).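

In this assay, 3-iodophenyl cannot be told apart from the other two substituted phenyl groups at this position, which lies between two ring nitrogen atoms: the exchange for 4-chlorophenyl gives a 1.5-fold higher number from compound 3 to compound 4 (0.17 log units; within the scatter) and the exchange for 4-methylphenyl gives a 1.6-fold higher number from compound 2 to compound 4 (0.20 log units; within the scatter), so a change of both the group and its place on the phenyl leaves no readable difference. Against the plain phenyl, iodo in place of hydrogen gives a 6.0-fold higher number from compound 1 to compound 4 (0.78 log units; beyond the scatter), which makes 3-iodophenyl a third substituted phenyl on the weaker side of compound 1, the first whose group does not sit where the chloro of compound 3 and the methyl of compound 2 sit, and none of the four compounds goes against this. (Nothing in the data shown accounts for this difference from the plain phenyl)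

The compounds shown leave open whether the identity of the group or its place on the phenyl counts for more, as no pair among them holds one fixed while the other changes. They also leave open how this phenyl behaves when it carries a hydroxyl, an amine or a carboxylic acid instead of iodo, chloro or methyl.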